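This account rests on a few compounds, and the source may have more. Where it says the series, first, only, none or still open, it means among the compounds named here.

For the measured compounds named here, in a functional assay on A549 cells (Homo sapiens) for antiproliferative activity, read by MTT assay, with a stated time of 48 h (a lower number here means a stronger inhibitor, a higher number a weaker inhibitor), only two compounds with this shared core have been measured so far. Compound 1 `Cc1ccc(Oc2nc3ccc(C)cc3cc2/C=N/NC(=O)Cn2c([N+](=O)[O-])cnc2C)cc1` gives 1190 nM, while compound 2 `Cc1ccc2nc(Oc3ccc(F)cc3)c(/C=N/NC(=O)Cn3c([N+](=O)[O-])cnc3C)cc2c1` gives 190 nM, the lower of the two numbers. Going by the values given here, the only measured step, a 6.3-fold lower number from compound 1 to compound 2 (0.80 log units; beyond the scatter), comes with fluoro in place of methyl on an aromatic carbon. Compound 3 `Cc1ccc2nc(Oc3ccc(Cl)cc3)c(/C=N/NC(=O)Cn3c([N+](=O)[O-])cnc3C)cc2c1` is changed at that same carbon: chloro in place of fluoro on an aromatic carbon. This puts chloro in place of fluoro, on a six-membered aromatic ring of carbon only, para to a large group. Among the compounds with values here, no measured pair shows this exact exchange, so the evidence is thin. Still, a 6.3-fold lower number from compound 1 to compound 2 (0.80 log units; beyond the scatter) shows that a change at this carbon can move the number noticeably. A modest rise is expected, a 1.8-fold higher number from compound 2 to compound 3 (0.27 log units; within the scatter), though it may not clear the scatter. Compound 3 is estimated at 350 nM, with an expected range of 120 nM to 1100 nM.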

Compound 3, half-maximal inhibitory concentration: 1230 nM
Compound 3: middle estimate off by 3.5-fold (0.55 log units), on the low side, and the stated range ends below it.
By their numbers in this assay, from the lowest: compound 2; then compounds 1 and 3 (each within the scatter of the next).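

In this assay the swap of fluoro for chloro on this aromatic carbon is far from a minor edit: it gives a 6.5-fold higher number from compound 2 to compound 3 (0.81 log units; beyond the scatter) and so cancels the whole advantage that compound 2 holds over compound 1. Chloro and methyl at this carbon cannot be told apart, as a 1.0-fold higher number from compound 1 to compound 3 (0.01 log units; within the scatter) lies within the scatter, so among the three groups shown only fluoro gives a clearly lower number. No measurement shown here explains why fluoro stands apart from chloro and methyl.

The compounds shown leave open how other groups on this carbon would compare, such as a methoxy group, an amine or a plain hydrogen. They also leave open whether bromo would follow chloro, and whether the 4-fluorophenoxy advantage would hold on a different core.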